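The source may report more compounds than this note shows. Statements on the series, on what has been measured and on what is new or still open speak of the compounds shown alone.

Compound 1 `C=CC(=O)Nc1cc(Nc2ncc3ncn(-c4ccc(C)cc4)c3n2)c(OC)cc1N(C)CCN(C)C` is the starting point of this step. Among the compounds with values here, in an ADME assay on HT-29 cells (Homo sapiens) for cytotoxicity, read by MTT assay, with a stated time of 72 h (a lower number here means a stronger inhibitor, a higher number a weaker inhibitor), compound 1 gives 9230 nM, the lowest of the three numbers measured so far. Compound 2 `C=CC(=O)Nc1cc(Nc2ncc3ncn(-c4ccc(I)cc4)c3n2)c(OC)cc1N(C)CCN(C)C` gives 9520 nM, and the change from compound 1 to compound 2 amounts to a 1.0-fold higher number from compound 1 to compound 2 (0.01 log units; within the scatter). Compound 3 `C=CC(=O)Nc1cc(Nc2ncc3ncn(-c4ccc(Cl)cc4Cl)c3n2)c(OC)cc1N(C)CCN(C)C` gives 20600 nM, with a 2.2-fold higher number from compound 1 to compound 3 (0.35 log units; beyond the scatter) and, from compound 2, a 2.2-fold higher number from compound 2 to compound 3 (0.34 log units; beyond the scatter).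

Compound 4 `C=CC(=O)Nc1cc(Nc2ncc3ncn(C4CCCC4)c3n2)c(OC)cc1N(C)CCN(C)C` differs from compound 1 in one place: cyclopentyl in place of 4-methylphenyl on an aromatic nitrogen. Within the data shown here, no measured step swaps an aromatic group for a non-aromatic ring at this position, so the nearest guidance comes from the other changes made on the same aromatic nitrogen, which moved the number by a 2.2-fold higher number from compound 1 to compound 3 (0.35 log units; beyond the scatter) and a 2.2-fold higher number from compound 2 to compound 3 (0.34 log units; beyond the scatter) at most, and by a 1.0-fold higher number from compound 1 to compound 2 (0.01 log units; within the scatter) in the remaining case. The change to compound 4 is therefore expected to be modest as well, with a 1.2-fold higher number from compound 1 to compound 4 (0.08 log units; within the scatter) as the estimated step in this assay. Compound 4 is expected to give about 11000 nM, within a range of 4500 nM to 27000 nM.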

Compound 4, half-maximal inhibitory concentration: 20900 nM
For compound 4 the middle estimate is 1.9-fold (0.28 log units) below the measured one; the range from low to high includes it.
By their numbers in this assay, from the lowest: compounds 1 and 2 (each within the scatter of the next); then compounds 3 and 4 (each within the scatter of the next).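

In this assay, putting the non-aromatic cyclopentyl on the aromatic nitrogen in place of 4-methylphenyl gives a 2.3-fold higher number from compound 1 to compound 4 (0.35 log units; beyond the scatter), and putting it in place of 4-iodophenyl gives a step of similar size, a 2.2-fold higher number from compound 2 to compound 4 (0.34 log units; beyond the scatter). Cyclopentyl and 2,4-dichlorophenyl, two quite different rings, show no real separation, with a 1.0-fold higher number from compound 3 to compound 4 (0.01 log units; within the scatter), so an aromatic ring at this position is not required for a number in the range seen so far. Nothing measured here explains these modest steps.

As far as these compounds go, whether a cyclohexyl ring, an open chain such as isopropyl, or a phenyl ring carrying a carboxylic acid or an amine would stay in this range remains open. So does whether this pattern would hold outside this one cell assay.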